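The source may hold more compounds than are shown below. What is called first, only, known or untested is meant among the compounds shown, and "the series" means these compounds.

In a physicochemical assay for permeability, using PAMPA (a lower number here means that the compound crosses the layer more slowly, a higher number that the compound crosses the layer faster), compound 2 `Cc1oc(-c2c(Cl)cccc2Cl)nc1CN1CCC(C(=O)NCCCN2C[C@H](C)C[C@H](C)C2)CC1` stands without a number, its result being "not determined" (no result reported) and so offering no starting point. Compound 4 `Cc1cccc(-c2nc(CN3CCC(C(=O)NCCCN4C[C@H](C)C[C@H](C)C4)CC3)c(C)o2)c1` departs from it at one place, described by 3-methylphenyl in place of 2,6-dichlorophenyl on an aromatic carbon in the following words: 3-methylphenyl in place of 2,6-dichlorophenyl on an aromatic carbon. Among the measured compounds shown here, no measured step covers this exchange. For the measured compounds named here, the only step available lies elsewhere in the molecule. In this assay compound 1 `Cc1ccccc1-c1nc(CN2CCC(C(=O)NCCCN3CCCCC3)CC2)c(C)o1` gives 34.5 10^-6 cm/s as its result, and compound 3 `Cc1ccccc1-c1nc(CN2CCC(C(=O)NCCCN3CC4CCCC(C4)C3)CC2)c(C)o1` gives 331 10^-6 cm/s as its result, which amounts to a 9.6-fold higher number from compound 1 to compound 3 (0.98 log units; beyond the scatter) and lies beyond the scatter. That step shows how widely values can differ among these compounds, but compound 4 keeps the saturated ring group of compound 2 on the chain, and that group matches neither compound 1 nor compound 3. With no number for compound 2, no size or direction can be expected for this step, so the estimate rests on the span of those two values and stays wide. The value expected for compound 4 is 120 10^-6 cm/s as a rough estimate, with an expected range from 30 10^-6 cm/s to 400 10^-6 cm/s in this measurement.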

Compound 4, apparent permeability: 279 10^-6 cm/s
The estimate for compound 4 lay 2.3-fold (0.37 log units) below the measured number; measured number inside the range.
By their numbers in this assay, from the lowest: compound 1; then compounds 4 and 3 (each within the scatter of the next).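

In this assay compound 2 has no number to set against compound 4, so the step between them cannot be read. The compounds shown leave open what 3-methylphenyl in place of 2,6-dichlorophenyl does to the read-out. Nothing at hand bears on this result.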